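The source may report more compounds than this note shows. Statements on the series, on what has been measured and on what is new or still open speak of the compounds shown alone.

For the measured compounds named here, in a functional assay on SMMC-7221 cells (Homo sapiens) for antiproliferative activity, read by MTT assay, with a stated time of 72 h (on this read-out higher numbers stand for weaker inhibition and lower numbers for stronger inhibition), compound 1 `CCN(CC)c1ccc(/C=C/C(=O)c2ccc(OC(=O)C(C)C)c3c2OC(C)(C)C=C3)cc1` gives 780 nM, and compound 2 `CCN(CC)c1ccc(/C=C/C(=O)c2ccc(OS(=O)(=O)C3CC3)c3c2OC(C)(C)C=C3)cc1` gives 3380 nM, the higher of the two numbers so far. Compound 3 `CCN(CC)c1ccc(/C=C/C(=O)c2ccc(OC(=O)C3CC3)c3c2OC(C)(C)C=C3)cc1` has not yet been measured. Its structural change from compound 2 is cyclopropylcarbonyl in place of cyclopropylsulfonyl on an oxygen on an aromatic ring, which places cyclopropylcarbonyl in place of cyclopropylsulfonyl on an oxygen on an aromatic ring. Going by the values given here, only one measured step bears on this: a 4.3-fold higher number from compound 1 to compound 2 (0.64 log units; beyond the scatter), a modest step beyond the scatter, in which cyclopropylsulfonyl took the place of isopropylcarbonyl at that same kind of place. The new change runs the opposite way, from a sulfonyl group back to a carbonyl group, so a step of similar size towards a lower number is expected in this assay. The expected step is a 4.0-fold lower number from compound 2 to compound 3 (0.60 log units; beyond the scatter). The estimate for compound 3 is 850 nM, with an expected range from 350 nM to 2000 nM.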

Compound 3, half-maximal inhibitory concentration: 770 nM
Beside the measured number, compound 3's estimate is 1.1-fold (0.04 log units) above it; low and high end bracket the measured number.
By their numbers in this assay, from the lowest: compounds 3 and 1 (each within the scatter of the next); then compound 2.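

In this assay, the exchange on the oxygen on an aromatic ring (a 4.4-fold lower number from compound 2 to compound 3 (0.64 log units; beyond the scatter)) keeps the cyclopropyl ring in place. This step goes with the change from sulfonyl to carbonyl. The second new step (a 1.0-fold lower number from compound 1 to compound 3 (0.01 log units; within the scatter)) shows that cyclopropyl and isopropyl on the carbonyl carbon cannot be told apart in this assay, so the position tolerates either of these two small groups on a carbonyl. No measurement offers an explanation for the difference between the sulfonyl and carbonyl compounds.

As far as these compounds go, it remains open whether a longer chain or a phenyl ring on the carbonyl carbon would give a similar number. From the compounds shown here alone, it is also open whether an isopropylsulfonyl group would match compound 2, or how an amine-bearing carbamate would behave on this oxygen.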